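Trifluoromethoxy in Place of Methoxy on a Shared Core

The source may report more compounds than this note shows. Statements on the series, on what has been measured and on what is new or still open speak of the compounds shown alone.

Of the compounds shown here, three on a shared core have been measured in a functional assay on the whole organism for inhibition, with Rattus norvegicus as the target, at a dose of 30 mg/kg; a higher number here means more inhibition at the dose given (going by the name of the read-out), a lower number less inhibition. Compound 1 `Cc1ccc(-c2nc3ncccc3o2)cc1` gives 5%, compound 2 `Fc1ccc(-c2nc3ncccc3o2)cc1` gives 28%, and compound 3 `COc1ccc(-c2nc3ncccc3o2)cc1` gives 14%. Compound 3 stands second highest of the three numbers, though its gap to compound 1 is within the scatter, while a number 14 percentage points lower from compound 2 to compound 3 (beyond the scatter) lies beyond it. The largest move seen is a number 23 percentage points higher from compound 1 to compound 2 (beyond the scatter). Compound 4 `FC(F)(F)Oc1ccc(-c2nc3ncccc3o2)cc1` differs from compound 3 by trifluoromethyl in place of methyl on an oxygen on an aromatic ring. Among the measured compounds shown here, no measured step covers this exact change, so the bearing steps are the two that exchange groups on an aromatic carbon and bring fluorine in or out: a number 23 percentage points higher from compound 1 to compound 2 (beyond the scatter) and a number 14 percentage points lower from compound 2 to compound 3 (beyond the scatter). Because a number 23 percentage points higher from compound 1 to compound 2 (beyond the scatter) and a number 14 percentage points lower from compound 2 to compound 3 (beyond the scatter) both leave the fluoro-bearing compound with the higher reading, a modest rise in this assay is expected for compound 4, as a number 10 percentage points higher from compound 3 to compound 4 (within the scatter). The estimate for compound 4 is 24%, with a range from 6% to 42%.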

Compound 4, a percentage reported as inhibition, in the whole organism at one dose (the size of the read-out at that dose, not a potency): 0%
The estimate for compound 4 lay 24 percentage points above the measured number; measured number outside the range, below it.
By their numbers in this assay, from the lowest: compounds 4, 1 and 3 (each within the scatter of the next, the first and the last beyond it); then compound 2.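

In this assay, trifluoromethyl in place of methyl on the oxygen gives a number 14 percentage points lower from compound 3 to compound 4 (beyond the scatter) and so shows that bringing fluorine into the group at this position does not in itself raise the reading. Trifluoromethoxy in place of fluoro gives a number 28 percentage points lower from compound 2 to compound 4 (beyond the scatter) and leaves compound 2 with the only reading beyond the scatter of all the others, while trifluoromethoxy in place of methyl gives a number 5 percentage points lower from compound 1 to compound 4 (within the scatter) and so separates those two compounds by nothing that can be read. No measurement shown here explains the drop.

The four compounds leave open whether the reading of compound 2 is particular to fluoro or would also appear with chloro on the same aromatic carbon. They also leave open how an amine or a carboxylic acid in that place would read in this assay at this dose.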